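From Chloro to Trifluoromethyl: Expecting Compound 4

The source may report more compounds than this note shows. Statements on the series, on what has been measured and on what is new or still open speak of the compounds shown alone.

Of the compounds shown here, three sharing one core have been measured in an ADME assay on A549 cells (Homo sapiens) for cytotoxicity, read by resazurin assay, with a stated time of 48 h; on this read-out higher numbers stand for lower toxicity in this test and lower numbers for higher toxicity in this test. Compound 1 (`O=C(Nc1ccc(NCC2CCCC2)cc1Cl)c1cc(Cl)ccc1O`), carrying cyclopentyl, gives 21500 nM, compound 2 (`O=C(Nc1ccc(NCc2ccccc2)cc1Cl)c1cc(Cl)ccc1O`), carrying phenyl, gives 19700 nM, and compound 3 (`O=C(Nc1ccc(NCc2ccc(Cl)cc2)cc1Cl)c1cc(Cl)ccc1O`), carrying 4-chlorophenyl, gives 59700 nM, the highest number of the three.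

Compound 4 (`O=C(Nc1ccc(NCc2ccc(C(F)(F)F)cc2)cc1Cl)c1cc(Cl)ccc1O`) departs from compound 3 in one place: trifluoromethyl in place of chloro on an aromatic carbon. This puts trifluoromethyl in place of chloro on an aromatic carbon, para to a large group.

Among the compounds with values here, two measured steps bear on this change. Adding the chloro gave a 3.0-fold higher number from compound 2 to compound 3 (0.48 log units; beyond the scatter), and the full exchange of cyclopentyl for 4-chlorophenyl gave a 2.8-fold higher number from compound 1 to compound 3 (0.44 log units; beyond the scatter). Both are modest, while the exchange of cyclopentyl for phenyl gave a 1.1-fold lower number from compound 1 to compound 2 (0.04 log units; within the scatter), which lies within the scatter. Within the data shown here, no measured step exchanges chloro for trifluoromethyl, so the size of this step remains uncertain, and no shift beyond the scatter is expected in this assay.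

The expected change is a 1.3-fold lower number from compound 3 to compound 4 (0.12 log units; within the scatter). Compound 4 is estimated at 45000 nM, with an expected range from 20000 nM to 100000 nM.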

Compound 4, half-maximal cytotoxic concentration: 62700 nM
The estimate for compound 4 lay 1.4-fold (0.14 log units) below the measured number, and the stated range covers the measured number.
By their numbers in this assay, from the lowest: compounds 2 and 1 (each within the scatter of the next); then compounds 3 and 4 (each within the scatter of the next).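

In this assay, the exchange on an aromatic carbon, para to a large group, gave a 1.1-fold higher number from compound 3 to compound 4 (0.02 log units; within the scatter), so this position did not separate trifluoromethyl from chloro, even though trifluoromethyl brings four heavy atoms where chloro brings one. Within the data shown here, measured against the earlier compounds, trifluoromethyl gave a 3.2-fold higher number from compound 2 to compound 4 (0.50 log units; beyond the scatter) in place of hydrogen and a 2.9-fold higher number from compound 1 to compound 4 (0.46 log units; beyond the scatter) when 4-(trifluoromethyl)phenyl replaced cyclopentyl, so a second group now matches the modest shift first seen with chloro. The data shown offer no evidence on why these two groups read alike.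

The compounds shown leave open whether fluoro, methoxy, an amine or a carboxylic acid at this place would read like chloro and trifluoromethyl or like hydrogen. They also leave open whether the same exchange would read alike on another core.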